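The source may hold more compounds than are shown below. What is called first, only, known or untested is meant among the compounds shown, and "the series" means these compounds.

Measured compounds:
- compound 1, `COc1ccnc(Nc2ccc(Cl)c(OCC=C(C)C)c2)n1`: 9000 nM
- compound 2, `CC(C)=CCOc1cc(Nc2nccc(C(F)(F)F)n2)ccc1Cl`: 2500 nM

Both numbers come from a functional assay on MT2 cells (Homo sapiens) for cytotoxicity; a higher number here means that more compound is tolerated, a lower number that less compound is tolerated. Among the compounds with values here, compound 2 stands as the lower of the two, and its only neighbour is compound 1, whose number is higher by the step of a 3.6-fold lower number from compound 1 to compound 2 (0.56 log units; beyond the scatter), a difference that sits beyond the scatter of repeated measurements.

Compound 3, `CSc1ccnc(Nc2ccc(Cl)c(OCC=C(C)C)c2)n1`, has not been measured yet. Its change from compound 2 is methylsulfanyl in place of trifluoromethyl on an aromatic carbon. Within the data shown here, the only measured step that bears on this position is the one from compound 1 to compound 2, which was modest in size and ran toward a lower number when trifluoromethyl replaced methoxy. Methylsulfanyl is neither of those groups, so the same step cannot simply be read across; what it shows is that a change at this carbon of the core can shift the number by a modest amount in either direction. Compound 3 is therefore expected to land near compound 2 or somewhat higher, with an estimated step of a 1.8-fold higher number from compound 2 to compound 3 (0.26 log units; within the scatter). The estimate for compound 3 is 4500 nM, within a range from 1800 nM to 11000 nM.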

Compound 3, half-maximal cytotoxic concentration: 2800 nM
Compound 3: the middle estimate sits 1.6-fold (0.21 log units) above what was measured, within the range that was stated.
By their numbers in this assay, from the lowest: compounds 2 and 3 (each within the scatter of the next); then compound 1.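

In this assay, methylsulfanyl and trifluoromethyl on this aromatic carbon, next to the ring nitrogen, cannot be told apart (a 1.1-fold higher number from compound 2 to compound 3 (0.05 log units; within the scatter)), even though the two groups differ in their atoms and in their heavy-atom count. The replacement of methoxy by methylsulfanyl is also modest and lies beyond the scatter (a 3.2-fold lower number from compound 1 to compound 3 (0.51 log units; beyond the scatter)), so the earlier step to trifluoromethyl is no longer the only change at this carbon to give a lower number than methoxy does, and among these three compounds, compound 1 stands apart while compound 2 and compound 3 sit together. Nothing available explains why methoxy separates from the other two groups.

The compounds shown leave open whether an amine, a carboxylic acid or a plain methyl on this carbon would fall with methoxy or with the other two groups, and whether a longer chain such as ethylsulfanyl would stay with methylsulfanyl. As far as these compounds go, all three compounds also share the rest of their structure, so whether the same grouping would hold with another group in place of the chlorine remains open as well.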